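Cyclohexyl for 2-Methoxyethyl: An Estimate for Compound 4

The compounds below may be only part of what the source reports. "The series", "measured", "known", "first", "only" and "open" are said of these compounds alone.

Measured compounds:
compound 1, `CO/N=C/c1c(N)ncnc1Oc1ccc2[nH]ccc2c1`, 783 nM
compound 2, `COCCCO/N=C/c1c(N)ncnc1Oc1ccc2[nH]c(C)cc2c1F`, 300 nM
compound 3, `CO/N=C/c1c(N)ncnc1Oc1ccc2[nH]cc(C)c2c1`, 132 nM

In a functional assay on A-375 cells (Homo sapiens) for antiproliferative activity (a lower number here means a stronger inhibitor, a higher number a weaker inhibitor), compound 2 stands second highest of the three numbers; its nearest neighbour is compound 3 with 132 nM, the furthest is compound 1 with 783 nM, both gaps beyond the scatter. Going by the values given here, the only step measured between compounds differing in one place is a 5.9-fold lower number from compound 1 to compound 3 (0.77 log units; beyond the scatter), methyl in place of hydrogen on an aromatic carbon. That step lies on the ring, not on the chain, and so bears only loosely on the present change.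

Compound 4, `Cc1cc2c(F)c(Oc3ncnc(N)c3/C=N/OCC3CCCCC3)ccc2[nH]1`, differs from compound 2 as follows: cyclohexyl in place of 2-methoxyethyl on a saturated chain carbon bound to an oxygen on an unsaturated carbon. The same difference, cut one bond further out, reads 3-methoxypropyl to cyclohexylmethyl. Among the compounds with values here, no measured pair shows a change in this chain, so the data give no direct guide to its size or direction.

The expectation is therefore a step from compound 2 to compound 4 of a 1.2-fold lower number from compound 2 to compound 4 (0.08 log units; within the scatter), within or near the scatter. Compound 4 is estimated at 250 nM in this assay, with a range from 80 nM to 900 nM.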

Compound 4, half-maximal inhibitory concentration: 4920 nM
Beside the measured number, compound 4's estimate is 20-fold (1.29 log units) below it; the whole stated range lies below it.
By their numbers in this assay, from the lowest: compound 3; then compound 2; then compound 1; then compound 4.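

The chain at this position is not a neutral handle in this assay: cyclohexyl in place of 2-methoxyethyl gives a 16-fold higher number from compound 2 to compound 4 (1.21 log units; beyond the scatter), a large step, and the first change shown on a saturated chain carbon bound to an oxygen on an unsaturated carbon. The earlier step, a 5.9-fold lower number from compound 1 to compound 3 (0.77 log units; beyond the scatter), lay on the ring and said nothing about this chain, whereas this pair shows that a group with one hydrogen-bond acceptor and no ring cannot be replaced freely by a six-membered carbon ring with no acceptor. Nothing in the available data accounts for this rise.

The pair changes the ring and the oxygen together, and the compounds shown leave open which of the two carries the step. Also open, from the compounds shown here alone, is how a chain bearing an amine or a carboxylic acid, or a longer chain, would read in this assay.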